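Notes on removing the fluoro group from compound 2

The source may report more compounds than this note shows. Statements on the series, on what has been measured and on what is new or still open speak of the compounds shown alone.

Measured so far in a functional assay on MDA-MB-231 cells (Homo sapiens) for inhibition, read by sulforhodamine B assay, with a stated time of 48 h; on this read-out lower numbers stand for stronger inhibition and higher numbers for weaker inhibition
- compound 1 `CCOC(=O)CO/N=C(/c1ccc(OC)c(OC)c1OC)c1cccc2ccccc12` gives 16400 nM
- compound 2 `COc1ccc(C(O)(Cc2ccc(F)cc2)c2cccc3ccccc23)c(OC)c1OC` gives 5440 nM

Compound 2 holds the lower of the two numbers in this assay, and its gap to compound 1 lies beyond the usual scatter. Within the data shown here, two compounds are too few to show any pattern, and no measured pair differs in one place.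

The next compound is compound 3 `COc1ccc(C(O)(Cc2ccccc2)c2cccc3ccccc23)c(OC)c1OC`, which departs from compound 2 at a single site: hydrogen in place of fluoro on an aromatic carbon. This is hydrogen in place of fluoro on an aromatic carbon, para to a large group, so 4-fluorobenzyl becomes benzyl.

Among the measured compounds shown here, no measured step speaks to this change directly, so its size remains a judgement. The expectation starts from compound 2 at 5440 nM, with no shift beyond the scatter anticipated in either direction. The expected change is a small rise, given as the estimated step of a 1.3-fold higher number from compound 2 to compound 3 (0.11 log units; within the scatter). For compound 3 the estimated value is 7000 nM, with an expected range from 2800 nM to 16000 nM.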

Compound 3, half-maximal inhibitory concentration: 4780 nM
For compound 3 the middle estimate is 1.5-fold (0.17 log units) above the measured one; measured number inside the range.
By their numbers in this assay, from the lowest: compounds 3 and 2 (each within the scatter of the next); then compound 1.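

Taking the fluoro group off the 4-fluorobenzyl group gives, in this assay, a 1.1-fold lower number from compound 2 to compound 3 (0.06 log units; within the scatter), the first step in the series between compounds that differ in one place. On this read-out, fluoro and hydrogen on this aromatic carbon, para to a large group, cannot be told apart, so the fluoro group is not needed to keep the number of compound 2 in this assay. No evidence at hand bears on this result, and nothing can be said about why the two compounds read alike.

Going by these compounds, the pair covers only fluoro and hydrogen, so it remains open whether a larger or differently built group at the same site, such as methoxy, an amine or a carboxylic acid, would leave the number within the scatter or shift it beyond. Also open is how the rest of the molecule contributes, for example what replacing the hydroxyl group on the carbon that carries the benzyl group with a methoxy group or a hydrogen would do, since the compounds shown offer no one-place step there.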